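Working notes on a two-compound series and one proposal

This account rests on a few compounds, and the source may have more. Where it says the series, first, only, none or still open, it means among the compounds named here.

Of the compounds shown here, two have been measured in a functional assay on HT-29 cells (Homo sapiens) for cytotoxicity, read by MTT assay, with a stated time of 24 h; on this read-out lower numbers stand for stronger inhibition and higher numbers for weaker inhibition. Compound 1 `O=Cc1ccc(OCc2cn(CCCOc3ccc4ccc(=O)oc4c3)nn2)cc1` gives 100000 nM. Compound 2 `COc1cccc(C=O)c1OCc1cn(CCCOc2ccc3ccc(=O)oc3c2)nn1` gives 13300 nM. For the measured compounds named here, the single measured step, a 7.5-fold lower number from compound 1 to compound 2 (0.88 log units; beyond the scatter), leaves compound 2 with the lowest of the two numbers, compound 1 being its only neighbour.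

Compound 3 `O=Cc1cc(Br)ccc1OCc1cn(CCCOc2ccc3ccc(=O)oc3c2)nn1` is not yet measured. It differs from compound 2 by 4-bromo-2-formylphenyl in place of 2-formyl-6-methoxyphenyl on an oxygen on a saturated carbon. Going by the values given here, no measured step bears directly on this change: the only step, from compound 1 to compound 2, changed the aromatic ring on an oxygen on a saturated carbon in a different way, and no bromine-bearing compound has been measured. That step shows the ring at this place can shift the number beyond the scatter, and the direction for the present change cannot be read from the data. For compound 3 in this assay a number close to that of compound 2 is expected, estimated at 20000 nM, within 5000 nM to 100000 nM. This expectation amounts to a 1.5-fold higher number from compound 2 to compound 3 (0.18 log units; within the scatter), which is not beyond the scatter.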

Compound 3, half-maximal inhibitory concentration: 7470 nM
Compound 3: middle estimate off by 2.7-fold (0.43 log units), on the high side; low and high end bracket the measured number.
By their numbers in this assay, from the lowest: compounds 3 and 2 (each within the scatter of the next); then compound 1.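

In this assay, 4-bromo-2-formylphenyl in place of 2-formyl-6-methoxyphenyl on an oxygen on a saturated carbon gives a 1.8-fold lower number from compound 2 to compound 3 (0.25 log units; within the scatter) and so cannot be told apart from it at this place. Set against 4-formylphenyl, the same ring gives a 13-fold lower number from compound 1 to compound 3 (1.13 log units; beyond the scatter) and thus shows that a second ring carrying a 2-formyl group, with bromo instead of methoxy as its other group, also stands clear of compound 1. Nothing on hand explains these numbers.

The compounds shown do not separate the placing of the formyl group from the added bromo or methoxy group, since compound 1 carries neither. In this assay, from the compounds shown here alone, it also stays open whether a carboxylic acid or an amine in place of the formyl group would keep or shift the number.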